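The source may report more compounds than this note shows. Statements on the series, on what has been measured and on what is new or still open speak of the compounds shown alone.

Compound 1 `O=[N+]([O-])c1c(CS(=O)(=O)c2ccccc2)nc2c(C#Cc3ccccc3)cc(Cl)cn12` in an ADME assay on HepG2 cells (Homo sapiens) for cytotoxicity, read by MTT assay, with a stated time of 72 h (on this read-out higher numbers stand for lower toxicity in this test and lower numbers for higher toxicity in this test), gives > 3900 nM, which is a limit of the assay rather than a number.
Compound 2 `COc1ccc(C#Cc2cc(Cl)cn3c([N+](=O)[O-])c(CS(=O)(=O)c4ccccc4)nc23)cc1` in this assay gives > 3900 nM, again a limit.
Compound 3 `O=[N+]([O-])c1c(CS(=O)(=O)c2ccccc2)nc2c(C#Cc3ccc(F)cc3)cc(Cl)cn12` in this assay gives > 3900 nM, also a limit.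

Compound 1 therefore stands only at a limit, and the two compounds made from it stand at the same one (the limit of > 3900 nM in this assay, at which 3 of the 3 values shown sit). Compound 4 `Nc1ccc(C#Cc2cc(Cl)cn3c([N+](=O)[O-])c(CS(=O)(=O)c4ccccc4)nc23)cc1` differs from compound 1 by amino in place of hydrogen on an aromatic carbon. The measured steps that bear on this change are a step that the two limits leave unreadable from compound 1 to compound 2 and a step that the two limits leave unreadable from compound 1 to compound 3, both of which have no readable size. No step beyond the scatter is therefore expected in this assay; compound 4 is expected to sit near the same limit, with an estimated step that the limit leaves unreadable from compound 1 to compound 4. The estimate for compound 4 is 6000 nM, in a range from 3900 nM to 12000 nM.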

Compound 4, half-maximal cytotoxic concentration: > 3900 nM
Compound 4: a limit, no number; the forecaster's own chance of this, stated with the estimate: 85%; the middle value does not contradict the limit.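

In this assay compound 4 gives > 3900 nM, again a limit. Its steps to compound 1, compound 2 and compound 3 therefore cannot be read: the limit of > 3900 nM in this assay, at which 4 of the 4 values shown sit.

From the compounds shown here alone, whether these four compounds differ at all in this read-out, and where their true values lie, stays open.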